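Swapping the ester group on a thiophene-bearing core

This account rests on a few compounds, and the source may have more. Where it says the series, first, only, none or still open, it means among the compounds named here.

For the measured compounds named here, compound 2 `CC1=C(C(=O)SC(C)C)C(c2cccs2)NC(=O)N1` carries the lowest of the two numbers so far in an assay on membranes from HeLa cells for displacement of a labelled ligand from adenosine receptor A3 (Homo sapiens), read by scintillation counting, with a stated time of 180 min, tested at 1 uM (a lower number here means less inhibition, a higher number more inhibition at the concentration tested (going by the name of the read-out)), where compound 2 gives 1%. Going by the values given here, the nearest comparison is compound 1 `COC(=O)C1=C(C)NC(=O)NC1c1cccs1`, which in this assay gives 3%; the only measured step, a number 2 percentage points lower from compound 1 to compound 2 (within the scatter), is within the scatter, so these two compounds cannot be told apart.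

Compound 3 `CC1=C(C(=O)OC2CCCCC2)C(c2cccs2)NC(=O)N1` differs from compound 2 by cyclohexyloxy in place of isopropylsulfanyl on a carbonyl carbon. Among the compounds with values here, the one measured step bears on this change only loosely, since it also altered the group on the carbonyl carbon and produced no shift beyond the scatter. With both measured compounds sitting at very low inhibition, no movement beyond the scatter is expected here either, and the step of a number 2 percentage points higher from compound 2 to compound 3 (within the scatter) is estimated to be negligible. Compound 3 is therefore expected to give about 3% in this assay, plausibly anywhere between -7% and 14%.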

Compound 3, a percentage reported as inhibition, at one concentration (the size of the read-out at that concentration, not a potency): 1%
For compound 3 the middle estimate is 2 percentage points above the measured one, and the stated range covers the measured number.
By their numbers in this assay, from the lowest: compounds 2, 3 and 1 (each within the scatter of the next).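

For the compounds shown here, compound 3 brings a ring of six carbons to this position for the first time, yet in this assay the swap from isopropylsulfanyl to cyclohexyloxy gives no change at the digits printed from compound 2 to compound 3 (within the scatter), and cyclohexyl in place of methyl on the oxygen gives a number 2 percentage points lower from compound 1 to compound 3 (within the scatter) as well. Within these three compounds, then, neither adding a ring nor enlarging the group on the carbonyl carbon lifts inhibition out of the scatter at the single concentration tested. No supporting measurement bears on why this position shows so little response.

On these data alone, whether a carboxylic acid, an amine or a benzyloxy group on this carbonyl carbon would give a clearly higher number stays open. So does whether changes elsewhere on the shared core would matter more than changes at this position.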